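The source may hold more compounds than are shown below. What is called first, only, known or untested is meant among the compounds shown, and "the series" means these compounds.

Compound 1 `COc1ccccc1N1C(=O)CSC1c1cccc(C(=O)NCCCCn2cccn2)c1`: 91.7 nM in a functional assay on HOS-TE85 cells (Homo sapiens) for inhibition, read by CCK-8 assay, with a stated time of 72 h; a higher number here means a weaker inhibitor, a lower number a stronger inhibitor
Compound 2 `CCOC(=O)c1sc(N2C(=O)CSC2c2cccc(C(=O)NCCCCn3cccn3)c2)nc1C`: 430 nM in this assay
Compound 3 `Cc1ccnc(N2C(=O)CSC2c2cccc(C(=O)NCCCCn3cccn3)c2)c1`: 19.6 nM in this assay

Compound 3 has the lowest number of the three in this assay: the step of a 4.7-fold lower number from compound 1 to compound 3 (0.67 log units; beyond the scatter) and the step of a 22-fold lower number from compound 2 to compound 3 (1.34 log units; beyond the scatter) are both beyond the scatter, so it is the strongest inhibitor measured here. Compound 4 `O=C(NCCCCn1cccn1)c1cccc(C2SCC(=O)N2c2cc(Br)ccn2)c1` keeps the whole of compound 3 except for one change: bromo in place of methyl on an aromatic carbon. Among the compounds with values here, none of the measured steps touches this spot; each of them swaps the entire group on the amide-type nitrogen, so they give no guide to a single-atom exchange on the 4-methylpyridin-2-yl ring. Within the data shown here, with no comparable step to draw on, the expectation is a step of a 1.3-fold higher number from compound 3 to compound 4 (0.11 log units; within the scatter) that stays within the scatter. Compound 4 is therefore estimated at 25 nM in this assay, with a range from 8 nM to 80 nM.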

Compound 4, half-maximal inhibitory concentration: 105 nM
The estimate for compound 4 lay 4.2-fold (0.62 log units) below the measured number; measured number outside the range, above it.
By their numbers in this assay, from the lowest: compound 3; then compounds 1 and 4 (each within the scatter of the next); then compound 2.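

Exchanging methyl for bromo on the carbon opposite the ring nitrogen is not a neutral swap in this assay (a 5.4-fold higher number from compound 3 to compound 4 (0.73 log units; beyond the scatter)), showing that this single position matters, which the earlier whole-group swaps could not reveal. With bromo there, the 4-bromopyridin-2-yl group no longer stands apart from 2-methoxyphenyl (a 1.1-fold higher number from compound 1 to compound 4 (0.06 log units; within the scatter)), though it still beats the substituted thiazolyl group (a 4.1-fold lower number from compound 2 to compound 4 (0.61 log units; beyond the scatter)). Nothing available explains the difference between methyl and bromo. As far as these compounds go, whether chloro, ethyl, methoxy or an amine at this carbon would track methyl or bromo remains open.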